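The source may report more compounds than this note shows. Statements on the series, on what has been measured and on what is new or still open speak of the compounds shown alone.

In a functional assay on Huh-7 cells (Homo sapiens) for antiproliferative activity, read by CCK-8 assay, with a stated time of 72 h (a lower number here means a stronger inhibitor of growth, a higher number a weaker inhibitor of growth), compound 1 `CCC1C(=O)N(C)c2cnc(-n3ccc4cc(C(=O)NC(C)C)ccc43)nc2N1c1ccn(C)n1` gives 6740 nM. Compound 2 `CCCNC(=O)c1ccc2c(ccn2-c2ncc3c(n2)N(c2ccn(C)n2)C(CC)C(=O)N3C)c1` carries the change (propyl in place of isopropyl on an amide-type nitrogen), and in this assay compound 2 gives 7280 nM, so that a 1.1-fold higher number from compound 1 to compound 2 (0.03 log units; within the scatter). Compound 3 `CC[C@@H]1C(=O)N(C)c2cnc(-n3ccc4cc(C(=O)NC(C)C)ccc43)nc2N1C1CCCC1` is built on a different core; how that core differs from the core of compound 1 is not broken down here. In this assay compound 3 gives 1660 nM, the lowest of the three numbers, and its distance from compound 1 is beyond the scatter. Compound 4 `CCCNC(=O)c1ccc2c(ccn2-c2ncc3c(n2)N(C2CCCC2)[C@H](CC)C(=O)N3C)c1` is related to compound 3 by propyl in place of isopropyl on an amide-type nitrogen, the same change that links compound 1 and compound 2. Because a 1.1-fold higher number from compound 1 to compound 2 (0.03 log units; within the scatter) stayed within the scatter, a similarly small step is expected here, a 1.1-fold higher number from compound 3 to compound 4 (0.04 log units; within the scatter). Compound 4 is therefore estimated at 1800 nM, between 900 nM and 3600 nM.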

Compound 4, concentration for 50% growth inhibition: 689 nM
Compound 4: middle estimate off by 2.6-fold (0.42 log units), on the high side, outside the stated range (below it).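

In this assay, propyl in place of isopropyl on an amide-type nitrogen gives a 2.4-fold lower number from compound 3 to compound 4 (0.38 log units; beyond the scatter), whereas the same change on the core of compound 1 stayed within the scatter, and the two steps compare as follows: the same change on two cores in this assay, a 1.1-fold higher number (0.03 log units; within the scatter) from compound 1 to compound 2 and a 2.4-fold lower number (0.38 log units; beyond the scatter) from compound 3 to compound 4, 2.6-fold (0.42 log units) apart, within the scatter of two such steps. The gap between them is therefore no firm sign that the two cores respond differently, yet it does not show that the step carries over unchanged either. Going by these compounds alone, with only two pairs in a single assay, no rule for the whole series follows. The compounds shown leave open how a longer chain such as butyl, or a cyclopropyl group, would read in that place. They also leave open whether an amine there would follow the same course on either core.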